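The compounds below may be only part of what the source reports. "The series", "measured", "known", "first", "only" and "open" are said of these compounds alone.

Measured compounds in a functional assay on HeLa cells (Homo sapiens) for cytotoxicity, read by WST assay, with a stated time of 48 h; a lower number here means a stronger inhibitor, a higher number a weaker inhibitor:
compound 1 `O[C@@H](c1ccccc1)[C@H]1CO[C@H](c2ccccc2)[C@@H](C/C=C/C2CCCCC2)C1` — 6440 nM
compound 2 `COc1cccc([C@@H]2OC[C@H]([C@@H](O)c3ccc(OC)c(OC)c3)C[C@H]2C/C=C/c2ccc(OC)c(OC)c2)c1` — 30100 nM
compound 3 `COc1ccc(/C=C/C[C@H]2C[C@@H]([C@@H](OC)c3ccc(OC)c(OC)c3)CO[C@@H]2c2ccc(OC)c(OC)c2)cc1OC` — > 100000 nM, which is a limit of the assay rather than a number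

Of the two numbers shown, compound 1 gives the lowest; compound 2 sits at a higher number, a gap beyond the usual scatter. Compound 3 reached only (the limit of > 100000 nM in this assay, at which 1 of the 3 values shown sits).

Compound 4 `O=[N+]([O-])c1cccc(/C=C/C[C@H]2C[C@@H]([C@@H](O)c3ccccc3)CO[C@@H]2c2ccccc2)c1` has not yet been measured. It differs from compound 1 in one place: 3-nitrophenyl in place of cyclohexyl on a double-bonded chain carbon bound to a double-bonded chain carbon. Among the measured compounds shown here, no measured pair shares this change, so the expectation rests on compound 1 alone, and the step from compound 1 to compound 4 in this assay is expected to be small, with no clear direction beyond the scatter, as a 1.2-fold higher number from compound 1 to compound 4 (0.09 log units; within the scatter). Compound 4 is therefore estimated at 8000 nM, within a range from 2000 nM to 40000 nM.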

Compound 4, half-maximal inhibitory concentration: 7850 nM
Beside the measured number, compound 4's estimate is 1.0-fold (0.01 log units) above it; the range from low to high includes it.
By their numbers in this assay, from the lowest: compounds 1 and 4 (each within the scatter of the next); then compound 2. At a limit, above all of these: compound 3.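

In this assay, the step is a 1.2-fold higher number from compound 1 to compound 4 (0.09 log units; within the scatter), so at this place on the chain, cyclohexyl and the larger, aromatic 3-nitrophenyl, which brings hydrogen-bond acceptors, cannot be told apart. This rests on a single pair, and nothing measured here gives a reason for the match. Still open, on these data alone, is whether a phenyl ring carrying an amine or a carboxylic acid at this place would stay at the same level. A longer chain between the double bond and the shared core is equally untested.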